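The source may report more compounds than this note shows. Statements on the series, on what has been measured and on what is new or still open speak of the compounds shown alone.

Measured in a functional assay on HT-29 cells (Homo sapiens); a higher number here means a weaker inhibitor of growth, a lower number a stronger inhibitor of growth:
compound 1 `O=S(=O)(/C=C/c1ccc(Cl)c(Cl)c1)Cc1ccc(Nc2ncnc3ccc(Br)cc23)cc1` gives 27000 nM
compound 2 `O=S(=O)(/C=C/c1ccc(O)cc1)Cc1ccc(Nc2ncnc3ccc(Br)cc23)cc1` gives 9000 nM
compound 3 `O=S(=O)(/C=C/c1ccc(Cl)cc1Cl)Cc1ccc(Nc2ncnc3ccc(Br)cc23)cc1` gives 28000 nM

Compound 3 stands level with compound 1 at the high end of these numbers, as the step of a 1.0-fold higher number from compound 1 to compound 3 (0.02 log units; within the scatter) shows, and it is clearly separated from compound 2 by the step of a 3.1-fold higher number from compound 2 to compound 3 (0.49 log units; beyond the scatter) in the same assay.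

The next compound, compound 4 `O=S(=O)(/C=C/c1ccc(F)cc1F)Cc1ccc(Nc2ncnc3ccc(Br)cc23)cc1`, differs from compound 3 by one change (2,4-difluorophenyl in place of 2,4-dichlorophenyl on a double-bonded chain carbon bound to a double-bonded chain carbon), which puts 2,4-difluorophenyl in place of 2,4-dichlorophenyl. For the measured compounds named here, no measured step makes this exact exchange. Compound 3 and compound 1 show that moving the two chlorines made no measurable difference, while compound 2 shows that the 4-hydroxyphenyl group gave only a modest step (a 3.0-fold lower number from compound 1 to compound 2 (0.48 log units; beyond the scatter)). A small shift toward a lower number is therefore the most that can be expected, and it may stay within the scatter. The expected step is a 1.4-fold lower number from compound 3 to compound 4 (0.15 log units; within the scatter) on this estimate. In this assay compound 4 is estimated at 20000 nM (range 9000 nM to 35000 nM).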

Compound 4, concentration for 50% growth inhibition: 100000 nM
Beside the measured number, compound 4's estimate is 5.0-fold (0.70 log units) below it, outside the stated range (above it).
By their numbers in this assay, from the lowest: compound 2; then compounds 1 and 3 (each within the scatter of the next); then compound 4.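

In this assay moving the two chlorines had made no measurable difference, yet exchanging them for fluorines on the same pattern does (a 3.6-fold higher number from compound 3 to compound 4 (0.55 log units; beyond the scatter)), so the identity of the halogen matters at this place where the chlorine pattern did not. For the compounds shown here, the step from the other dichlorophenyl compound runs the same way (a 3.7-fold higher number from compound 1 to compound 4 (0.57 log units; beyond the scatter)), and the one from the hydroxyphenyl compound is large (an 11-fold higher number from compound 2 to compound 4 (1.05 log units; beyond the scatter)), which leaves compound 4 as the weakest of the four, with all its steps beyond the scatter. No evidence is available to explain this loss.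

Going by these compounds, it remains open whether a 3,4-difluorophenyl group would match compound 4 or compound 1, which would show whether the fluorine pattern matters. Also open, on these data alone, is whether a methoxy or an amine in place of the hydroxyl of compound 2 would hold its lower number.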